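Phenethyl in Place of 4-Ethylphenyl on the Sulfur

The source may report more compounds than this note shows. Statements on the series, on what has been measured and on what is new or still open speak of the compounds shown alone.

Compound 1, `Nc1ccccc1NC(=O)c1ccc(CSc2ccc(Br)cc2)cc1`, gives 4.35% in a functional assay on A-375 cells (Homo sapiens) for inhibition, read by CCK-8 assay, with a stated time of 72 h, tested at 2 uM; a higher number here means more inhibition of growth at the concentration tested, a lower number less inhibition of growth.
Compound 2, `COc1ccc(SCc2ccc(C(=O)Nc3ccccc3N)cc2)cc1`, gives 10.2% in this assay.
Compound 3, `CCc1ccc(SCc2ccc(C(=O)Nc3ccccc3N)cc2)cc1`, gives 19.6% in this assay.

Compound 3 stands highest of the three numbers in this assay. The step of a number 9.4 percentage points higher from compound 2 to compound 3 (within the scatter) lies within the scatter, as does a number 5.9 percentage points higher from compound 1 to compound 2 (within the scatter), whereas a number 15.3 percentage points higher from compound 1 to compound 3 (beyond the scatter) lies beyond it, though only modestly.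

Compound 4, `Nc1ccccc1NC(=O)c1ccc(CSCCc2ccccc2)cc1`, differs from compound 3 by phenethyl in place of 4-ethylphenyl on a sulfur. Within the data shown here, every measured step changes a group on the aromatic ring that leaves here; none alters the link at the sulfur, so no measured step bears directly on this change. With the whole measured spread modest, compound 4 is expected to stay near the values seen, with an expected step of a number 6.6 percentage points lower from compound 3 to compound 4 (within the scatter) not beyond the scatter. Compound 4 is therefore estimated at 13%, in a range from 2% to 26%.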

Compound 4, percent growth inhibition at one concentration: 21.8%
Compound 4: the middle estimate sits 8.8 percentage points below what was measured; measured number inside the range.
By their numbers in this assay, from the lowest: compounds 1, 2, 3 and 4 (each within the scatter of the next, the first and the last beyond it).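

Replacing 4-ethylphenyl with phenethyl on the sulfur gives a number 2.2 percentage points higher from compound 3 to compound 4 (within the scatter) in this assay, so this position tolerates the same atoms joined differently without a step beyond the scatter. Phenethyl in place of 4-methoxyphenyl gives a number 11.6 percentage points higher from compound 2 to compound 4 (beyond the scatter) and in place of 4-bromophenyl gives a number 17.5 percentage points higher from compound 1 to compound 4 (beyond the scatter), the first steps at this position that alter the link at the sulfur and exceed the scatter, though both are modest. Nothing available explains these steps. Going by these compounds, whether a longer chain in place of phenethyl, or an amine or a carboxylic acid on its aromatic ring, would move the number remains open.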